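Acetamido for methyl in an almost inactive series

This account rests on a few compounds, and the source may have more. Where it says the series, first, only, none or still open, it means among the compounds named here.

Measured in a functional assay on HepG2 cells (Homo sapiens) for antiproliferative activity, read by MTT assay, with a stated time of 48 h (a higher number here means a weaker inhibitor, a lower number a stronger inhibitor), as follows:
Compound 1 `COc1ccc(-c2c(Nc3ccc(NC(C)=O)cc3)c3ccccc3oc2=O)cc1` gives > 100000 nM as a limit
Compound 2 `COc1ccc(-c2c(Nc3ccc(F)cc3)c3ccc(OC)cc3oc2=O)cc1` gives > 100000 nM as a limit
Compound 3 `COc1ccc(-c2c(Nc3ccc(C)cc3)c3ccc(OC)cc3oc2=O)cc1` gives 74400 nM as a number

Among the compounds with values here, compound 3 at 74400 nM holds the only real number here. The other two values sit at the limit of > 100000 nM in this assay, at which 2 of the 3 values shown sit, and nothing finer is known of them.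

Compound 4 `COc1ccc(-c2c(Nc3ccc(NC(C)=O)cc3)c3ccc(OC)cc3oc2=O)cc1` carries acetamido in place of methyl on an aromatic carbon, para to a large group, and the count of that change is acetamido in place of methyl on an aromatic carbon when set against compound 3.

Within the data shown here, the one measured step is an at least 1.3-fold lower number from compound 2 to compound 3 (0.12 log units; that floor lies within the scatter) and it swaps methyl for fluoro, so it offers only a floor and not a true size. It says little about acetamido.

Compound 1 carries the acetamido group too and gives > 100000 nM as a limit of the assay, so no large drop is expected for compound 4, and a limit may again be all that is reported.

In this assay the estimated move is a 1.1-fold higher number from compound 3 to compound 4 (0.06 log units; within the scatter) and that means no change beyond the scatter is expected.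

For compound 4 the estimate is 85000 nM with an expected range from 25000 nM to 150000 nM if a number is reported at all.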

Compound 4, half-maximal inhibitory concentration: > 100000 nM
Compound 4 was reported as a limit (the forecaster's own chance of this, stated with the estimate: 50%); middle value at least 1.1-fold (0.07 log units) away from the limit.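

Putting acetamido in place of methyl on this aromatic carbon gives an at least 1.3-fold higher number from compound 3 to compound 4 (0.12 log units; that floor lies within the scatter), measured in this assay, so the step has a floor but no true size, and that floor does not separate the two compounds. Within the data shown here, until now acetamido had been seen only on the core of compound 1, which lacks the second methoxy; compound 4 shows that with this methoxy present, acetamido still gives no number, and its steps to compound 1 and compound 2 join two limits and cannot be read. Compound 4 therefore adds to the values that can only be read as a limit of the assay, not as a measured potency: the limit of > 100000 nM in this assay, at which 3 of the 4 values shown sit.

Compound 3 remains the only compound here with a real number, so the compounds shown do not reveal how far any change at this position can move the result in either direction. From the compounds shown here alone, whether an amine, a carboxylic acid or a longer chain in place of the methyl of compound 3 would give a number clearly different from that of compound 3 stays open.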